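A Second Methoxy Group: From Compound 2 to Compound 3

The compounds below may be only part of what the source reports. "The series", "measured", "known", "first", "only" and "open" are said of these compounds alone.

Among the measured compounds shown here, compound 2 `COc1ccc(/C=C/c2cc(C)n[nH]2)cc1` stands at the lower of the two numbers measured so far: in an ADME assay on NIH3T3 cells (Mus musculus) for cytotoxicity, read by MTT assay, with a stated time of 72 h (a higher number here means a weaker inhibitor, a lower number a stronger inhibitor), compound 2 gives 19900 nM. For the measured compounds named here, its only neighbour is compound 1 `Cc1cc(/C=C/c2ccc(O)cc2)[nH]n1`, which in this assay gives 59200 nM, and the step of a 3.0-fold lower number from compound 1 to compound 2 (0.47 log units; beyond the scatter) is the single measured change in this set. Compound 3 `COc1ccc(/C=C/c2cc(C)n[nH]2)cc1OC` has not yet been measured. It differs from compound 2 in one place: methoxy in place of hydrogen on an aromatic carbon. Going by the values given here, no measured step covers the entry of a methoxy group at an aromatic carbon; the step of a 3.0-fold lower number from compound 1 to compound 2 (0.47 log units; beyond the scatter) concerns a methyl in place of hydrogen on an oxygen and bears on the present change only loosely, so its direction cannot be read from the data with confidence. The expected step for compound 3 is therefore a 1.3-fold lower number from compound 2 to compound 3 (0.12 log units; within the scatter), close to the scatter. For compound 3 the estimate in this assay is 15000 nM, within a range from 6000 nM to 40000 nM.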

Compound 3, half-maximal inhibitory concentration: 68400 nM
Compound 3: the middle estimate sits 4.6-fold (0.66 log units) below what was measured; the whole stated range lies below it.
By their numbers in this assay, from the lowest: compound 2; then compounds 1 and 3 (each within the scatter of the next).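

In this assay, methoxy in place of hydrogen on an aromatic carbon, ortho to a methoxy group and meta to a group of 8 heavy atoms, gives a 3.4-fold higher number from compound 2 to compound 3 (0.54 log units; beyond the scatter). Among the compounds shown here, this is the only measured change at an aromatic carbon of this ring, and it shows that the position responds to substitution beyond the scatter. For the compounds shown here, its direction is upward, whereas the only other step, a change on an oxygen, runs the other way: a 3.0-fold lower number from compound 1 to compound 2 (0.47 log units; beyond the scatter). Nothing available gives a reason for the rise.

Going by these compounds, whether the rise belongs to methoxy in particular remains open, since a fluorine, an amine or a longer alkoxy chain at this carbon could move the number differently. Also open, on these data alone, is whether methoxy would give a similar step at another carbon of the ring.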